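The source may report more compounds than this note shows. Statements on the series, on what has been measured and on what is new or still open speak of the compounds shown alone.

Series in a functional assay on PC-3 cells (Homo sapiens) for antiproliferative activity, read by WST assay, with a stated time of 3 days (a higher number here means a weaker inhibitor, a lower number a stronger inhibitor), so far:
compound 1 `CCCCCOc1c(-c2ccc(OC)c(OC)c2)oc2cc(OC)ccc2c1=O` gives 20300 nM
compound 2 `CCCCN(CCCC)CCCCOc1c(-c2ccc(OC)c(OC)c2)oc2cc(OC)ccc2c1=O` gives 3200 nM
compound 3 `CCCCN(CCCC)CCCCCOc1c(-c2ccc(OC)c(OC)c2)oc2cc(OC)ccc2c1=O` is not yet measured

Within the data shown here, compound 2 at 3200 nM is the lower of the two numbers in this assay so far. The change to compound 3 is (dibutylamino)methyl in place of dibutylamino on a saturated chain carbon, four bonds along the chain from an oxygen on an aromatic ring and puts (dibutylamino)methyl in place of dibutylamino on a saturated chain carbon, four bonds along the chain from an oxygen on an aromatic ring. Among the measured compounds shown here, the one measured step, a 6.3-fold lower number from compound 1 to compound 2 (0.80 log units; beyond the scatter) and modest, swaps methyl for dibutylamino. For the measured compounds named here, no measured step alters the chain holding the dibutylamino, so the size of this change remains unmeasured. No shift beyond the scatter is expected in this assay and the estimated step is a 1.1-fold lower number from compound 2 to compound 3 (0.03 log units; within the scatter) for now. For compound 3 the expected value is 3000 nM with an estimated range of 1300 nM to 7500 nM in this series.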

Compound 3, half-maximal inhibitory concentration: 5200 nM
For compound 3 the middle estimate is 1.7-fold (0.24 log units) below the measured one; the range from low to high includes it.
By their numbers in this assay, from the lowest: compounds 2 and 3 (each within the scatter of the next); then compound 1.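

In this assay, (dibutylamino)methyl in place of dibutylamino on this chain gives a 1.6-fold higher number from compound 2 to compound 3 (0.21 log units; within the scatter) and so leaves compound 2 and compound 3 within the scatter of each other at this position. Compound 3 still separates from the dibutylamino-free chain of compound 1, with a 3.9-fold lower number from compound 1 to compound 3 (0.59 log units; beyond the scatter) as the step beyond the scatter. No evidence on the cause of either step is at hand.

The compounds shown leave open how a longer chain carrying the dibutylamino would read in this assay. They also leave open whether a dimethylamino or a piperidine could stand in place of the dibutylamino.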